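The compounds below may be only part of what the source reports. "The series", "measured", "known", "first", "only" and "open" are said of these compounds alone.

Compound 1, with the structure `Cc1ccc(COc2ccc(C(=O)NC(=S)Nc3ccc(C)c(-c4nc5ccccc5[nH]4)c3)cc2)cc1`, is the starting point. In a functional assay on MNK45 cells (Homo sapiens) for inhibition, read by MTT assay, with a stated time of 48 h (a lower number here means a stronger inhibitor, a higher number a weaker inhibitor), compound 1 gives 11300 nM. Compound 2, with the structure `Cc1ccc(NC(=S)NC(=O)c2ccc(OCc3ccc(F)cc3)cc2)cc1-c1nc2ccccc2[nH]1`, differs from it in one place only: fluoro in place of methyl on an aromatic carbon. That single exchange gives a 2.7-fold lower number from compound 1 to compound 2 (0.43 log units; beyond the scatter), so the cell-growth reading of compound 2 is 4220 nM.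

Compound 3, with the structure `Cc1ccc(COc2ccc(C(=O)NC(=O)Nc3ccc(Cl)c(-c4nc5ccccc5[nH]4)c3)cc2)cc1`, belongs to a second core; how its core differs from the core of compound 1 is not broken down here. In this assay compound 3 gives 3190 nM. The values of compound 2 and compound 3 lie within the scatter of each other, so nothing separates them; compound 1, however, stands beyond the scatter from compound 3.

Compound 4, with the structure `O=C(NC(=O)c1ccc(OCc2ccc(F)cc2)cc1)Nc1ccc(Cl)c(-c2nc3ccccc3[nH]2)c1`, is not yet measured. It differs from compound 3 by fluoro in place of methyl on an aromatic carbon, the same change that leads from compound 1 to compound 2, at the same kind of place on the ring. Among the measured compounds shown here, the one measured example of this change, the step from compound 1 to compound 2, is the only guide, and it rests on a single pair, so some caution is due. The expectation is a step of about a 2.1-fold lower number from compound 3 to compound 4 (0.33 log units; beyond the scatter), a little smaller than the measured one, because compound 3 already gives 3190 nM, a lower number than that of compound 1, and a repeated gain of equal size is not guaranteed. The estimated value for compound 4 in this assay is 1500 nM, most likely between 600 nM and 3500 nM.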

Compound 4, half-maximal inhibitory concentration: 350 nM
Compound 4: middle estimate off by 4.3-fold (0.63 log units), on the high side; measured number outside the range, below it.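

In this assay, putting 4-fluorobenzyl in place of 4-methylbenzyl again lowers the number, giving a 9.1-fold lower number from compound 3 to compound 4 (0.96 log units; beyond the scatter), so the direction of the change is the same on the core of compound 1 and on the core of compound 3. The size of the change does not carry over, however, as the two steps lie further apart than two such steps would by scatter alone: the same change on two cores in this assay, a 2.7-fold lower number (0.43 log units; beyond the scatter) from compound 1 to compound 2 and a 9.1-fold lower number (0.96 log units; beyond the scatter) from compound 3 to compound 4, 3.4-fold (0.53 log units) apart, beyond the scatter of two such steps. Among the compounds shown here, with only two pairs, this shows that a step measured on one core need not predict the size of the same step on another, but it does not show which feature of the two cores goes with the larger step, nor why the steps differ.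

The core of compound 3 differs from that of compound 1 in two visible ways, with a carbonyl in place of a thiocarbonyl and a chloro in place of the methyl on the core, and the compounds shown leave open which of these, if either, goes with the larger step. Also open, from the compounds shown here alone, is how a methoxy group, a nitrile or a plain hydrogen would read in place of the fluoro on either core.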